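Swapping the anilide ring on a weak growth inhibitor

The source may report more compounds than this note shows. Statements on the series, on what has been measured and on what is new or still open speak of the compounds shown alone.

The account follows compound 2 `O=C(COc1ccc(/C=C2\SC(=O)NC2=O)cc1)Nc1ccc(F)cc1F` to compound 3 `Cc1ccc(NC(=O)COc2ccc(/C=C3\SC(=O)NC3=O)cc2)cc1Cl`. Compound 2 stands at the edge of what can be measured: in a functional assay on PC-3 cells (Homo sapiens) for inhibition (a lower number here means a stronger inhibitor of growth, a higher number a weaker inhibitor of growth), compound 2 gives > 100000 nM, which is a limit of the assay and not a number. Its measured neighbour is compound 1 `O=C(COc1ccc(/C=C2\SC(=O)NC2=O)cc1)Nc1ccc(Cl)cc1`, and in this assay compound 1 gives 83400 nM. Going by the values given here, the one measured step, an at least 1.1-fold higher number from compound 1 to compound 2 (0.07 log units; that floor lies within the scatter), has a floor that lies within the scatter, and compound 2 sits at the limit of > 100000 nM in this assay, at which 1 of the 2 values shown sits.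

The change from compound 2 to compound 3 is 3-chloro-4-methylphenyl in place of 2,4-difluorophenyl on an amide-type nitrogen. Among the compounds with values here, only the step from compound 1 to compound 2 bears on this change, and it was no larger than the scatter allows, so no movement beyond the scatter is expected in this assay in either direction; compound 3 is expected to remain a weak inhibitor of growth, and it may again be reported only as a limit. Compound 3 is therefore estimated at 90000 nM in this assay, with a range from 40000 nM to 200000 nM. The expected step is an at least 1.1-fold lower number from compound 2 to compound 3 (0.04 log units; that floor lies within the scatter).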

Compound 3, concentration for 50% growth inhibition: > 100000 nM
Compound 3: no number, only a limit; the forecaster's own chance of this, stated with the estimate: 45%; middle value at least 1.1-fold (0.04 log units) from the limit.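

In this assay compound 3 gives > 100000 nM, which is a limit of the assay and not a number. Replacing the 2,4-difluorophenyl group with 3-chloro-4-methylphenyl therefore adds a second limit at this amide-type nitrogen, and the step between compound 2 and compound 3 cannot be read, as neither compound has a number. Against the one numbered compound, the result is an at least 1.1-fold higher number from compound 1 to compound 3 (0.07 log units; that floor lies within the scatter), so this change, like the earlier one, shows no difference beyond the scatter but does not rule one out, and the series now sits mostly at the edge of what can be measured: the limit of > 100000 nM in this assay, at which 2 of the 3 values shown sit.

The compounds shown leave open how far the true values of compound 2 and compound 3 lie past the limit, and so whether these two anilide rings differ at all. They also leave open whether a phenyl ring carrying a carboxylic acid or an amine on this amide-type nitrogen would bring the growth inhibition into a clearly measurable range.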